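The compounds below may be only part of what the source reports. "The series", "measured", "known", "first", "only" and "open" are said of these compounds alone.

Going by the values given here, in an ADME assay on the whole organism (strain Sprague-Dawley) for pharmacokinetics, with Rattus norvegicus as the target, using cassette dosing, at a dose of 1 mg/kg by the oral route (a lower number here means that a smaller share of the oral dose reaches the circulation, a higher number that a larger share of the oral dose reaches the circulation), compound 2 `O[C@]1(Cc2cc(-c3cn[nH]c3)on2)CC[C@H](Cc2ccc(Cl)cc2)CC1` gives 72.8% and stands highest of the two numbers so far, while compound 1 `O=c1ccc(-c2cc(C[C@]3(O)CC[C@@H](Cc4ccc(Cl)cc4)CC3)no2)c[nH]1` gives 37.2% and is the nearest. Compound 3 `O[C@]1(Cc2cc(-c3cn[nH]c3)on2)CC[C@H](Cc2ccc(C(F)(F)F)cc2)CC1` differs from compound 2 at one place: trifluoromethyl in place of chloro on an aromatic carbon, para to a large group. Among the compounds with values here, the only measured step is a number 35.6 percentage points higher from compound 1 to compound 2 (beyond the scatter), a large one that lies at another place in the structure. Within the data shown here, no measured step covers the change at hand, so that size does not carry over, though it shows how far this read-out can move. With nothing pointing either way, the estimate stays close to the value of compound 2, and no step beyond the scatter is expected in this assay. The expected step is a number 4.8 percentage points lower from compound 2 to compound 3 (within the scatter), within the scatter. For compound 3 the estimated value is 68%, with an expected range from 45% to 88%.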

Compound 3, oral bioavailability: 67.5%
Compound 3: middle estimate off by 0.5 percentage points, on the high side; low and high end bracket the measured number.
By their numbers in this assay, from the lowest: compound 1; then compounds 3 and 2 (each within the scatter of the next).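

Trifluoromethyl in place of chloro on the aromatic carbon para to a large group gives a number 5.3 percentage points lower from compound 2 to compound 3 (within the scatter) in this assay, the first reading at this position. Four heavy atoms in place of one therefore leave the share of the oral dose reaching the circulation within the scatter for this pair, unlike a number 35.6 percentage points higher from compound 1 to compound 2 (beyond the scatter) at another place in the structure. Nothing available explains why this exchange gives no step beyond the scatter.

Only chloro and trifluoromethyl are shown at this position, so the reading for an amine, a carboxylic acid or a longer chain there remains open. Going by these compounds alone, also open is whether the same exchange would stay within the scatter with the group of compound 1 in place of the one shared by compound 2 and compound 3.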